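The source may report more compounds than this note shows. Statements on the series, on what has been measured and on what is new or still open speak of the compounds shown alone.

Measured compounds:
compound 1 `CCCc1ccc(NC(=S)N2CCC(C(O)(c3ccccc3)c3ccccc3)CC2)cc1`; in a functional assay for antagonist activity at Neuropeptide Y receptor type 2 (Homo sapiens) (on this read-out lower numbers stand for stronger inhibition and higher numbers for weaker inhibition), compound 1 gives 777 nM
compound 2 `OC(c1ccccc1)(c1ccccc1)C1CCN(C(=S)Nc2ccc(C(F)(F)F)cc2)CC1`; in this assay compound 2 gives 178 nM
compound 3 `CCNC(=O)c1ccc(NC(=S)N2CCC(C(O)(c3ccccc3)c3ccccc3)CC2)cc1`; in this assay compound 3 gives 206 nM

Compound 2 has the lowest number of the three, but it cannot be set apart from compound 3, since a 1.2-fold higher number from compound 2 to compound 3 (0.06 log units; within the scatter) stays within the scatter. Only compound 1 stands clearly apart: a 4.4-fold lower number from compound 1 to compound 2 (0.64 log units; beyond the scatter) and a 3.8-fold lower number from compound 1 to compound 3 (0.58 log units; beyond the scatter) are both beyond the scatter and of similar size.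

Compound 4 `CN(C)C(=O)c1ccc(NC(=S)N2CCC(C(O)(c3ccccc3)c3ccccc3)CC2)cc1` is not yet measured. Relative to compound 2 the change is dimethylcarbamoyl in place of trifluoromethyl on an aromatic carbon. Among the compounds with values here, the steps that bear on it are the two from compound 1, which show that trifluoromethyl and ethylcarbamoyl in this position behave alike against propyl, and the step between compound 2 and compound 3, which shows that swapping trifluoromethyl for a carbamoyl group changes nothing beyond the scatter. Within the data shown here, no measured step tests a carbamoyl lacking the amide hydrogen, so that part of the change is unsupported by data. The expectation for compound 4 in this assay is therefore a step of a 1.4-fold higher number from compound 2 to compound 4 (0.15 log units; within the scatter), that is, no change beyond the scatter. Compound 4 is estimated at 250 nM, with a range of 100 nM to 650 nM.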

Compound 4, half-maximal inhibitory concentration: 301 nM
For compound 4 the middle estimate is 1.2-fold (0.08 log units) below the measured one; the range from low to high includes it.
By their numbers in this assay, from the lowest: compounds 2, 3 and 4 (each within the scatter of the next); then compound 1.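

In this assay, dimethylamino in place of ethylamino on the carbonyl carbon leaves the read-out within the scatter (a 1.5-fold higher number from compound 3 to compound 4 (0.16 log units; within the scatter)), so the measured activity at this position does not depend on the amide hydrogen. Dimethylcarbamoyl also cannot be separated from trifluoromethyl (a 1.7-fold higher number from compound 2 to compound 4 (0.23 log units; within the scatter)), yet it remains clearly better than propyl (a 2.6-fold lower number from compound 1 to compound 4 (0.41 log units; beyond the scatter)), which makes it the third group at this position to give a modest step beyond the scatter from compound 1 while compounds 2, 3 and 4 stay within the scatter of one another. No measurement here explains why these three groups cannot be told apart or why propyl stands apart from them.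

Still open, going by these compounds, is whether a carboxylic acid, a primary amine or a longer chain on the amide nitrogen would stay with compounds 2, 3 and 4 in this assay or fall back towards compound 1. Also open, on these data alone, is whether any other group on this aromatic carbon, such as a nitrile or a sulfonamide, can give a step beyond the scatter from compound 2.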